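Series notes: amine end-group swap on the side chain

This account rests on a few compounds, and the source may have more. Where it says the series, first, only, none or still open, it means among the compounds named here.

Measured so far:
- compound 1 `O=c1cc(-c2ccccc2)oc2cc(OCc3ccccc3)c(OCCCCN3CCCCC3)c(O)c12`, 1900 nM in a functional assay on A549 cells (Homo sapiens) for antiproliferative activity, read by MTT assay, with a stated time of 48 h; a higher number here means a weaker inhibitor, a lower number a stronger inhibitor
- compound 2 `CN1CCN(CCCCOc2c(OCc3ccccc3)cc3oc(-c4ccccc4)cc(=O)c3c2O)CC1`, 4400 nM in this assay

Among the measured compounds shown here, compound 2 stands as the highest of the two numbers so far; the nearest is compound 1, and the step of a 2.3-fold higher number from compound 1 to compound 2 (0.36 log units; beyond the scatter) lies beyond the scatter, though it is modest.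

The next compound, compound 3 `CCN(CC)CCCCOc1c(OCc2ccccc2)cc2oc(-c3ccccc3)cc(=O)c2c1O`, is not yet measured in this assay. Its change from compound 2 is diethylamino in place of 4-methylpiperazin-1-yl on a saturated chain carbon, four bonds along the chain from an oxygen on an aromatic ring. For the measured compounds named here, the only measured step that bears on it is a 2.3-fold higher number from compound 1 to compound 2 (0.36 log units; beyond the scatter), which replaced piperidin-1-yl with 4-methylpiperazin-1-yl at the same place and raised the number modestly. Compound 3 carries diethylamino, which shares with piperidin-1-yl a single nitrogen and no second hetero atom, so the step from compound 2 is expected to reverse part of that rise, landing the number nearer compound 1 than compound 2.

The number for compound 3 is therefore estimated at 2500 nM, with a range of 1200 nM to 5500 nM, which corresponds to an expected step of a 1.8-fold lower number from compound 2 to compound 3 (0.25 log units; within the scatter).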

Compound 3, half-maximal inhibitory concentration: 1800 nM
Compound 3: middle estimate off by 1.4-fold (0.14 log units), on the high side; low and high end bracket the measured number.
By their numbers in this assay, from the lowest: compounds 3 and 1 (each within the scatter of the next); then compound 2.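

In this assay the end group need not be a ring to give this level, since diethylamino in place of piperidin-1-yl at this position gives a 1.1-fold lower number from compound 1 to compound 3 (0.02 log units; within the scatter) and leaves compound 1 and compound 3 level. The change from 4-methylpiperazin-1-yl to diethylamino gives a 2.4-fold lower number from compound 2 to compound 3 (0.39 log units; beyond the scatter) at the same place, so compound 2 now stands apart from two different end groups rather than one, and among these three compounds the two end groups with a single nitrogen sit together, with none going against this. No available measurement accounts for this grouping.

Going by these compounds, whether the higher number of compound 2 goes with the second ring nitrogen or with its methyl stays open, and morpholine or unsubstituted piperazine at the chain end would help separate the two. Also open, on these data alone, is whether compound 1 and compound 3 would remain level on a shorter or longer chain, and whether a smaller amine such as dimethylamino would fall at the same level.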